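Side-chain saturation in a set of weakly active analogues

The compounds below may be only part of what the source reports. "The series", "measured", "known", "first", "only" and "open" are said of these compounds alone.

Measured compounds:
Compound 1 `CCCC/C=C\CCCCCCCCCc1cc(=O)c2c(O)c(C)c(OCOC)cc2o1` — in a functional assay on MCF7 cells (Homo sapiens) for antiproliferative activity, read by MTT assay (a higher number here means a weaker inhibitor, a lower number a stronger inhibitor), compound 1 gives only a limit, > 67200 nM.
Compound 2 `CCCCCCCCCCCCCCCc1cc(=O)c2c(O)c(C)c(OCOC)cc2o1` — in this assay compound 2 gives only a limit, > 67200 nM.
Compound 3 `CCCC/C=C\CCCCCCCCCc1cc(=O)c2c(O)c(C)c(O)c(C)c2o1` — in this assay compound 3 gives only a limit, > 67200 nM.

Going by the values given here, the single change made between measured compounds is hexyl in place of hex-1-en-1-yl on a saturated chain carbon, nine bonds along the chain from an aromatic carbon. Its step, a step that the two limits leave unreadable from compound 1 to compound 2, cannot be sized, as both ends are limits of the assay. Compound 3 and compound 1 differ in more than one place; the difference between the two cores is not broken down here. Compound 4 `CCCCCCCCCCCCCCCc1cc(=O)c2c(O)c(C)c(O)c(C)c2o1` carries the same change relative to compound 3, (hexyl in place of hex-1-en-1-yl on a saturated chain carbon, nine bonds along the chain from an aromatic carbon), at the same place as before. Among the compounds with values here, all three values so far sit at one limit (the limit of > 67200 nM in this assay, at which 3 of the 3 values shown sit). In this assay the step from compound 3 to compound 4 is expected to be a step that the limit leaves unreadable from compound 3 to compound 4, an expectation that rests on the unreadable step that the two limits leave unreadable from compound 1 to compound 2 and on the limit (the limit of > 67200 nM in this assay, at which 3 of the 3 values shown sit). Compound 4 is expected near 100000 nM, within 50000 nM to 300000 nM, and most likely to be reported again only as a limit.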

Compound 4, half-maximal inhibitory concentration: > 67200 nM
Compound 4 gave a limit, no number (the forecaster's own chance of this, stated with the estimate: 85%); the middle value is on the limit's open side.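

In this assay compound 4 gives only a limit, > 67200 nM. Going by these compounds alone, the step between compound 3 and compound 4 therefore cannot be read, and neither can the one between compound 1 and compound 2. The compounds shown leave open whether hexyl in place of hex-1-en-1-yl changes potency at all, as no value here is a number: the limit of > 67200 nM in this assay, at which 4 of the 4 values shown sit.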